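The source may report more compounds than this note shows. Statements on the series, on what has been measured and on what is new or still open speak of the compounds shown alone.

Working notes on the series, read in a functional assay on cells (Endothelial cell, Sus scrofa) for antiproliferative activity; on this read-out higher numbers stand for weaker inhibition and lower numbers for stronger inhibition. Compound 2 `CO[C@@H]1[C@H](OC(=O)NC(=O)c2ccccc2)CO[C@]2(COC(C)(C)O2)[C@@]1(O)C1(C)CO1` gives 363000 nM, the highest number among the three measured compounds. Compound 1 `CO[C@@H]1[C@H](OC(=O)NC(=O)CCl)CO[C@]2(COC(C)(C)O2)[C@@]1(O)C1(C)CO1` gives 57000 nM. For the measured compounds named here, compound 3 `CO[C@@H]1[C@H](OC(=O)NC(=O)CCl)CO[C@]2(COC(C)(C)O2)[C@@]1(OC(=O)NC(=O)CCl)C1OC1CCCc1ccccc1`, which carries further changes, gives 16000 nM, the lowest number so far.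

The next structure is compound 4 `CNC(=O)O[C@@H]1CO[C@]2(COC(C)(C)O2)[C@@](O)(C2(C)CO2)[C@@H]1OC`, which departs from compound 2 as follows: methyl in place of benzoyl on an amide-type nitrogen. In words, this is methyl in place of benzoyl on an amide-type nitrogen.

Going by the values given here, only one measured step bears on this change: a 6.4-fold higher number from compound 1 to compound 2 (0.80 log units; beyond the scatter), with phenyl in place of chloromethyl on a carbonyl carbon. That step is modest but beyond the scatter, and it shows the number responding to the group carried on that carbonyl. Among the compounds with values here, it is only partial guidance, since compound 4 has no such carbonyl at all and no measured compound has methyl on that nitrogen. A single step also establishes no pattern. Compound 3 differs in too many places to isolate this change.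

A modest move towards a lower number is therefore expected, with an estimated 2.4-fold lower number from compound 2 to compound 4 (0.38 log units; beyond the scatter). Compound 4 is estimated at 150000 nM, with an expected range of 40000 nM to 500000 nM.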

Compound 4, half-maximal inhibitory concentration: 195000 nM
Beside the measured number, compound 4's estimate is 1.3-fold (0.11 log units) below it; measured number inside the range.
By their numbers in this assay, from the lowest: compound 3; then compound 1; then compounds 4 and 2 (each within the scatter of the next).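

In this assay, methyl in place of benzoyl on the amide-type nitrogen gives a 1.9-fold lower number from compound 2 to compound 4 (0.27 log units; within the scatter), so the numbers for these two groups cannot be told apart, even though the benzoyl group brings a six-membered aromatic ring and a carbonyl that methyl lacks. Methyl in place of (chloromethyl)carbonyl on the same nitrogen gives a 3.4-fold higher number from compound 1 to compound 4 (0.53 log units; beyond the scatter), so compound 1 now stands apart from two different groups at this position rather than from benzoyl alone, and the earlier step could not show this. Nothing available explains why the (chloromethyl)carbonyl group differs from the other two groups at this nitrogen.

The compounds shown leave open whether that difference needs the chlorine, the carbonyl or both, a question that an acetyl group or a bromoacetyl group on the nitrogen would address. They also leave open how a longer chain such as propyl, or a carboxylic acid on that chain, would read at this nitrogen, and what part of the number of compound 3 comes from this position.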